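The compounds below may be only part of what the source reports. "The series", "measured", "known", "first", "only" and "open" are said of these compounds alone.

Measured so far:
- compound 1 `Nc1nc(Cl)c2ncn(Cc3ccccc3CCl)c2n1`: 10000 nM
- compound 2 `ClCc1cccc(Cn2cnc3nc(Cl)nc(Cl)c32)c1`: 3630 nM

Two compounds have numbers in a functional assay on NCI-H226 cells (Homo sapiens) for cytotoxicity, read by sulforhodamine B assay, with a stated time of 48 h; a higher number here means a weaker inhibitor of growth, a lower number a stronger inhibitor of growth. Compound 1 gives 10000 nM, the highest of the two. Compound 2 gives 3630 nM, a lower number that lies beyond the usual scatter, so compound 2 is the stronger inhibitor of growth of the pair. Going by the values given here, no step between compounds differing in one place has been measured, so the size of any single change is still open.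

The next compound is compound 3 `ClCc1ccccc1Cn1cnc2c(Cl)nc(Cl)nc21`. It differs from compound 1 by chloro in place of amino on an aromatic carbon. Compound 2 shares the same chloro-bearing core and gives the lower number, so compound 3 is expected to move down from compound 1, by a step of about a 2.5-fold lower number from compound 1 to compound 3 (0.40 log units; beyond the scatter), beyond the scatter but not far. Compound 3 is thus estimated at 4000 nM, with a range from 1500 nM to 10000 nM.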

Compound 3, concentration for total growth inhibition: 3380 nM
For compound 3 the middle estimate is 1.2-fold (0.07 log units) above the measured one, within the range that was stated.
By their numbers in this assay, from the lowest: compounds 3 and 2 (each within the scatter of the next); then compound 1.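

Notes on the series: in this assay, this is the first step that changes a single place, and it isolates the aromatic carbon between two ring nitrogen atoms. Chloro in place of amino at this carbon gives a 3.0-fold lower number from compound 1 to compound 3 (0.47 log units; beyond the scatter) and so lowers the number by a modest amount, beyond the scatter. Growth inhibition in this assay therefore does not depend on keeping the amino group here, although no measurement shown explains the step.

The compounds shown leave open how a methoxy group, a dimethylamino group or a plain hydrogen on this carbon would compare with chloro and amino. Also open, as far as these compounds go, is whether the step would keep its size with the chloromethyl group at another position on the benzene ring.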